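The source may hold more compounds than are shown below. What is called first, only, known or untested is meant among the compounds shown, and "the series" means these compounds.

Measured in a functional assay on MDA-MB-435 cells (Homo sapiens) for cytotoxicity, read by sulforhodamine B assay, with a stated time of 48 h, tested at 1 uM; a higher number here means a weaker effect of the compound at the concentration tested, a lower number a stronger effect:

Compound 1 `COc1ccc(-c2cc(/C=C/C(=O)c3ccc(N)cc3)[nH]n2)cc1OC`: compound 1 gives 94%
Compound 2 `COc1ccc(-c2cc(/C=C/C(=O)c3cc(OC)c(OC)c(OC)c3)[nH]n2)cc1OC`: compound 2 gives 85%
Compound 3 `COc1ccc(C(=O)/C=C/c2cc(-c3cc(OC)c(OC)c(OC)c3)n[nH]2)cc1`: compound 3 gives 92%

All three compounds share a core in which a pyrazole-bearing chain carries a carbonyl and an aryl group, and all three leave most of the cells alive at the single concentration tested. Compound 3 stands between the other two on the numbers: its value lies closest to that of compound 1 and a little further from that of compound 2, yet both gaps fall within the usual scatter, so none of the three can be told apart on this evidence. No pair of these compounds differs in just one place, so no single step can be read off.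

Compound 4 `COc1cc(-c2cc(/C=C/C(=O)c3ccc(F)c(F)c3)[nH]n2)cc(OC)c1OC` has not yet been measured in this assay. It differs from compound 3 in one place: 3,4-difluorophenyl in place of 4-methoxyphenyl on a carbonyl carbon. Within the data shown here, nothing among the measured compounds shows what such an exchange does here, so no step beyond the scatter is expected, and the expected step of a number 2 percentage points lower from compound 3 to compound 4 (within the scatter) is small. Compound 4 is therefore estimated to give about 90%, most likely within 75% to 102%.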

Compound 4, a percentage reported as activity, at one concentration (the size of the read-out at that concentration, not a potency): 88%
Compound 4: the middle estimate sits 2 percentage points above what was measured; measured number inside the range.
By their numbers in this assay, from the lowest: compounds 2, 4, 3 and 1 (each within the scatter of the next).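

In this assay, the exchange of 4-methoxyphenyl for 3,4-difluorophenyl on a carbonyl carbon is the first change among these compounds that can be read in one place, and it amounts to a number 4 percentage points lower from compound 3 to compound 4 (within the scatter). At this position, then, an aromatic ring carrying a methoxy group and one carrying fluorine atoms cannot be told apart at the single concentration tested, so compound 4 shows no sign of the stronger effect on these cells that a real gain would bring. Nothing available here explains why the read-out stays within the scatter across this exchange.

On these data alone, it remains open whether any group on this carbonyl carbon can move the read-out beyond the scatter, for example a phenyl ring carrying a carboxylic acid or a nitrile, or a longer chain of carbon atoms in place of the ring. A single concentration also leaves open how compound 3 and compound 4 would compare at other concentrations, where a difference hidden here might or might not appear.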